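Series notes: side-chain exchange on the shared core

A few compounds are considered here, and "the series" means these few. Any claim that something is new, unique, unknown or untested is made for them only; others in the source may bear on it.

Compound 2 `N=C(N)NCCC[C@H](NC(=O)CN(c1nc(Cl)nc2[nH]cnc12)C1CC1)C(=O)OCc1ccccc1` gives 30.4% in a functional assay on the whole organism (Tail, strain ICR) with Mus musculus as the target, in the tail flick test, with a stated time of 90 min, at a dose of 25 umol/kg by the oral route; a lower number here means a weaker effect, a higher number a stronger effect of the compound at the dose given. Within the data shown here, that is the lower of the two numbers measured so far; compound 1 `O=C(CN(c1nc(Cl)nc2[nH]cnc12)C1CC1)N[C@@H](CO)C(=O)OCc1ccccc1` gives 34.5% in this assay, and the difference between the two lies within the scatter, so no order between them can be stated.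

The next compound, compound 3 `O=C(CN(c1nc(Cl)nc2[nH]cnc12)C1CC1)N[C@@H](CC(=O)OCc1ccccc1)C(=O)OCc1ccccc1`, is not yet measured in this assay. It differs from compound 2 at the same position where compound 1 and compound 2 differ: a group of 10 heavy atoms (8 carbon, 2 oxygen; one six-membered aromatic ring of carbon only) in place of a group of 6 heavy atoms (3 carbon, 3 nitrogen; no ring), on a saturated chain carbon, two bonds along the chain from an amide-type nitrogen and a carbonyl carbon

Among the measured compounds shown here, the one measured step that bears on this position is a number 4.1 percentage points lower from compound 1 to compound 2 (within the scatter), a change at the saturated chain carbon two bonds along the chain from the amide-type nitrogen and the carbonyl carbon that left the read-out essentially unchanged. For the measured compounds named here, with only that step as guide, the expectation for the exchange from compound 2 to compound 3 in this assay is again a step within the scatter, with no direction beyond it: a number 1.6 percentage points higher from compound 2 to compound 3 (within the scatter).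

Compound 3 is therefore expected to give about 32% in this assay, estimated between 18% and 46%.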

Compound 3, a percentage reported as activity, at one dose (the size of the read-out at that dose, not a potency): 15.6%
For compound 3 the middle estimate is 16.4 percentage points above the measured one, outside the stated range (below it).
By their numbers in this assay, from the lowest: compound 3; then compounds 2 and 1 (each within the scatter of the next).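

At the saturated chain carbon two bonds along the chain from an amide-type nitrogen and a carbonyl carbon, the read-out in this assay proves sensitive to the group carried there: benzyloxycarbonyl gives a clear drop against both earlier groups (a number 14.8 percentage points lower from compound 2 to compound 3 (beyond the scatter); a number 18.9 percentage points lower from compound 1 to compound 3 (beyond the scatter)), so the position is not indifferent to exchange, as the first pair alone suggested. Among these three compounds, the one group with a six-membered aromatic ring of carbon only and no hydrogen-bond donors stands lowest, while the two ring-free groups, hydroxy and the group of 6 heavy atoms, remain within the scatter of each other despite their different sizes. No measurement here accounts for the drop.

Because the aromatic ring, the carbonyl and the loss of hydrogen-bond donors all enter together in compound 3, the compounds shown cannot separate their contributions. A benzyl group or a free carboxylic acid at this place would begin to show which part of benzyloxycarbonyl goes with the lower read-out.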